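This account rests on a few compounds, and the source may have more. Where it says the series, first, only, none or still open, it means among the compounds named here.

Compound 1, `COC(=O)c1ccc(NCc2cncn2Cc2ccc(Cl)cc2)cc1-c1ccccc1`: 25000 nM.
Compound 2, `c1ccc(-c2ccc(Cn3cncc3CNc3ccc(-c4ccccc4)c(-c4ccccc4)c3)cc2)cc1`: a limit, > 10000 nM.
Compound 3, `COC(=O)c1ccc(NCc2cncn2Cc2cccc(OC)c2)cc1-c1ccccc1`: no result, "not determined" (no result reported).

Three compounds share a core and differ in the groups hung on it. In a toxicity assay on NIH3T3 cells (Mus musculus) for cytotoxicity, read by resazurin assay (on this read-out higher numbers stand for an effect only at larger amounts of compound and lower numbers for an effect already at smaller amounts), compound 1 gives 25000 nM. For compound 2 the read-out in this assay is only a limit, > 10000 nM. Compound 3 has no number at all in this assay, its entry reading "not determined" (no result reported); among the values shown for the others, one sits at the limit of > 10000 nM in this assay, at which 1 of the 3 values shown sits. Compound 4, `COC(=O)c1ccc(NCc2cncn2Cc2cccc(C(C)(C)C)c2)cc1-c1ccccc1`, differs from compound 3 by tert-butyl in place of methoxy on an aromatic carbon. Among the compounds with values here, no step between measured compounds is known here, so in this assay this change is expected to shift the result by no more than the usual scatter, in no set direction. Compound 4 is therefore estimated to give about 20000 nM, between 8000 nM and 50000 nM.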

Compound 4, half-maximal effective concentration: > 1000 nM
Compound 4: a limit, no number; the forecaster's own chance of this, stated with the estimate: 45%; the middle value lies beyond the limit too.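

Within the data shown here, compound 4 gives only a limit, > 1000 nM, so no step from compound 1 to compound 4 can be read. The compounds shown leave open whether 3-(tert-butyl)phenyl in place of 4-chlorophenyl shifts the result at all.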